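The source may hold more compounds than are shown below. What is called first, only, known or untested is meant among the compounds shown, and "the series" means these compounds.

Compound 1 `CCOc1cc(/C=C2\SC(=O)NC2=O)ccc1OCC1(C)CCc2c(C)c(OCC=C(C)C)c(C)c(C)c2O1` gives 84% in a functional assay on MCF7 cells (Homo sapiens), tested at 5 uM; a lower number here means a stronger effect, a higher number a weaker effect of the compound at the concentration tested. Compound 2 `C=CCOc1c(C)c(C)c2c(c1C)CCC(C)(COc1ccc(/C=C3\SC(=O)NC3=O)cc1OCC)O2` gives 87%. Compound 3 `Cc1c(C)c2c(c(C)c1OC(=O)CCC(=O)O)CCC(C)(COc1ccc(/C=C3\SC(=O)NC3=O)cc1)O2` gives 98%.

Compound 1 stands lowest of the three numbers in this assay. Its nearest neighbour is compound 2: a number 3 percentage points higher from compound 1 to compound 2 (within the scatter), the change being vinyl in place of 2-methylprop-1-en-1-yl on a saturated chain carbon bound to an oxygen on an aromatic ring. The furthest is compound 3, whose number lies beyond the scatter from that of compound 1; the two compounds differ in more than one place, so only their two values can be set side by side.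

Compound 4 `CC(C)=CCOc1c(C)c(C)c2c(c1C)CCC(C)(COc1ccc(/C=C3\SC(=O)NC3=O)cc1-c1ccc(F)cc1)O2` has not yet been measured in this assay. It arises from compound 1 by a single change, (4-fluorophenyl in place of ethoxy on an aromatic carbon). Within the data shown here, the one measured step concerns a saturated chain carbon elsewhere in the molecule and stayed within the scatter; no measured step touches the aromatic carbon in question or brings in a six-membered aromatic ring of carbon only. The data thus give no direct guide to this step, and the expectation is of no change beyond the scatter, with a wide range. Compound 4 is therefore expected to give about 83%, between 68% and 96%. The expected step is a number 1 percentage points lower from compound 1 to compound 4 (within the scatter), in no firm direction.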

Compound 4, a percentage reported as activity, at one concentration (the size of the read-out at that concentration, not a potency): 92%
Beside the measured number, compound 4's estimate is 9 percentage points below it; measured number inside the range.
By their numbers in this assay, from the lowest: compounds 1, 2, 4 and 3 (each within the scatter of the next, the first and the last beyond it).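

In this assay, the aromatic carbon that is ortho to a large group takes 4-fluorophenyl in place of ethoxy, and the outcome is a number 8 percentage points higher from compound 1 to compound 4 (within the scatter). Among these compounds, the entering group has 7 heavy atoms and a six-membered aromatic ring of carbon only, against 3 heavy atoms and no ring for ethoxy, so this exchange at the aromatic carbon does not separate the two numbers beyond the scatter, which the only other step, a number 3 percentage points higher from compound 1 to compound 2 (within the scatter), could not show because it concerns a saturated chain carbon elsewhere in the molecule. Nothing shown here bears on why the number responds to this exchange as it does.

As far as these compounds go, with a single exchange at this aromatic carbon, it remains open whether an amine, a carboxylic acid or a longer alkoxy chain such as butoxy there would carry the number beyond the scatter of compound 1. From the compounds shown here alone, it also remains open whether 4-fluorophenyl would give a similar step on the core of compound 2, or whether a phenyl ring without fluorine would read the same as 4-fluorophenyl.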